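Swapping an Ester for a Carbamate on a Dehydrogenase Inhibitor

The source may report more compounds than this note shows. Statements on the series, on what has been measured and on what is new or still open speak of the compounds shown alone.

Measured so far:
compound 1, `CCCC[S+]([O-])c1sc2nc(-c3nccs3)cc(-c3ccc(C(=O)OC)cc3)c2c1N`, 15.1 nM
compound 2, `COCCC[S+]([O-])c1sc2nc(-c3nccs3)cc(-c3cnc(C)n3C)c2c1N`, 3.3 nM
compound 3, `CCCCS(=O)(=O)c1sc2nc(-c3cccs3)cc(-c3ccccc3)c2c1N`, 25 nM

All three were tested in an assay for inhibition of 15-hydroxyprostaglandin dehydrogenase [NAD(+)] (Homo sapiens), read by fluorescence, with a stated time of 15 min, in the presence of a further agent that is not named here; on this read-out lower numbers stand for stronger inhibition and higher numbers for weaker inhibition. Compound 1 holds the second highest of the three numbers. Its nearest neighbour is compound 3, whose value lies within the usual scatter, so the two cannot be told apart. Compound 2 stands furthest away, with a clearly lower number, beyond the scatter.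

Compound 4, `CCCC[S+]([O-])c1sc2nc(-c3nccs3)cc(-c3ccc(COC(=O)NCC)cc3)c2c1N`, has not yet been measured. It keeps the core of compound 1 and differs in one place: ((ethylcarbamoyl)oxy)methyl in place of methoxycarbonyl on an aromatic carbon. Among the measured compounds shown here, no measured pair shows what such a change does to the read-out, so no direction can be read from the data. A modest step is expected, likely within the scatter, with perhaps a slightly lower number. The estimated step is a 1.3-fold lower number from compound 1 to compound 4 (0.10 log units; within the scatter). In this assay compound 4 is expected to give about 12 nM, with a range from 3 nM to 50 nM.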

Compound 4, half-maximal inhibitory concentration: 3.4 nM
Compound 4: middle estimate off by 3.5-fold (0.55 log units), on the high side; the measured number falls inside the stated range.
By their numbers in this assay, from the lowest: compounds 2 and 4 (each within the scatter of the next); then compounds 1 and 3 (each within the scatter of the next).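

In this assay, ((ethylcarbamoyl)oxy)methyl in place of methoxycarbonyl on an aromatic carbon para to a large group gives a 4.4-fold lower number from compound 1 to compound 4 (0.65 log units; beyond the scatter), a step beyond the usual scatter. This shows that the group at this position of the six-membered aromatic ring of carbon only can change the read-out, and that the larger group with a hydrogen-bond donor goes with the lower number here. Nothing given here explains the drop, so its cause remains unknown.

This single step cannot separate the effect of the added ethyl chain from that of the carbamate link or its hydrogen-bond donor. It also leaves open what a carboxylic acid, a hydroxymethyl group, an amine or a longer chain would give at this position.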